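Methoxy-to-hydrogen swap on a thiazole ketone series

The source may hold more compounds than are shown below. What is called first, only, known or untested is meant among the compounds shown, and "the series" means these compounds.

Compound 2 `COc1ccc(-c2nc(C)c(C(=O)CSc3nc(-c4ccc(Cl)c(Cl)c4)c(C#N)c(=O)[nH]3)s2)cc1` carries a methoxy group; compound 1 `Cc1nc(-c2ccccc2)sc1C(=O)CSc1nc(-c2ccc(Cl)c(Cl)c2)c(C#N)c(=O)[nH]1` is its counterpart with hydrogen in place of methoxy on an aromatic carbon. In a functional assay on U-87MG ATCC cells for antiproliferative activity against U-87 MG (Homo sapiens), read by MTT assay, with a stated time of 48 h (a lower number here means a stronger inhibitor, a higher number a weaker inhibitor), compound 2 gives 68500 nM, and compound 1 gives 65000 nM; the step is a 1.1-fold lower number from compound 2 to compound 1 (0.02 log units; within the scatter). Compound 3 `COc1ccc(-c2nc(SCC(=O)c3sc(-c4ccc(Cl)cc4)nc3C)nc(N)c2C#N)cc1` is built on a different core, and the difference between the two cores is not broken down here. In this assay compound 3 gives 10600 nM, the lowest of the three numbers, beyond the scatter from both compound 1 and compound 2.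

Compound 4 `Cc1nc(-c2ccc(Cl)cc2)sc1C(=O)CSc1nc(N)c(C#N)c(-c2ccccc2)n1` has not yet been measured. It differs from compound 3 by hydrogen in place of methoxy on an aromatic carbon, the same change as that between compound 2 and compound 1, at the same place. The earlier step was within the scatter. In this assay compound 4 is expected to give 9500 nM, with a likely range from 4000 nM to 25000 nM. This expectation rests on compound 3 at 10600 nM and on the earlier step of a 1.1-fold lower number from compound 2 to compound 1 (0.02 log units; within the scatter). The step this estimate implies, a 1.1-fold lower number from compound 3 to compound 4 (0.05 log units; within the scatter), is expected to stay within the scatter.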

Compound 4, half-maximal inhibitory concentration: 11400 nM
Compound 4: middle estimate off by 1.2-fold (0.08 log units), on the low side; measured number inside the range.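

In this assay, hydrogen in place of methoxy on the aromatic carbon gives a 1.1-fold higher number from compound 3 to compound 4 (0.03 log units; within the scatter), so on this second core, as on the first, the swap leaves the number within the scatter. Set side by side, the two steps do not differ: the same change on two cores in this assay, a 1.1-fold lower number (0.02 log units; within the scatter) from compound 2 to compound 1 and a 1.1-fold higher number (0.03 log units; within the scatter) from compound 3 to compound 4, 1.1-fold (0.05 log units) apart, within the scatter of two such steps This shows that the absence of a readable step carries from one core to the other, in this one assay and at this one place, as 4-methoxyphenyl to phenyl; it does not show that a step of readable size would carry over, since neither core provides one, and two cores cannot speak for the whole series.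

The compounds shown leave open whether a different group at the same place, such as a carboxylic acid, an amine or a longer alkoxy chain like butoxy, would move the number on either core. What separates the two cores also stays unresolved, as no pair shown differs there in one place alone.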